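The source may report more compounds than this note shows. Statements on the series, on what has been measured and on what is new or still open speak of the compounds shown alone.

Compound 2 `C=CC(=O)Nc1cc(Nc2ncc3ncn(-c4ccc(F)c(Cl)c4)c3n2)c(OC)cc1N(C)CCN(C)C` holds the lowest of the two numbers recorded so far in an ADME assay on HT-29 cells (Homo sapiens) for cytotoxicity, read by MTT assay, with a stated time of 72 h; on this read-out higher numbers stand for weaker inhibition and lower numbers for stronger inhibition: compound 2 gives 1610 nM, whereas compound 1 `C=CC(=O)Nc1cc(Nc2ncc3ncn(-c4ccccc4Cl)c3n2)c(OC)cc1N(C)CCN(C)C` gives 11300 nM. For the measured compounds named here, the single measured step between them, a 7.0-fold lower number from compound 1 to compound 2 (0.85 log units; beyond the scatter), exchanges one aromatic ring for another on the same aromatic nitrogen. Compound 3 `C=CC(=O)Nc1cc(Nc2ncc3ncn(C4CCCC4)c3n2)c(OC)cc1N(C)CCN(C)C` is still unmeasured; it differs from compound 2 by cyclopentyl in place of 3-chloro-4-fluorophenyl on an aromatic nitrogen. Going by the values given here, no measured step bears directly on this kind of change: the only step on record moves from one aromatic ring to another, and it shows merely that the group on this nitrogen can shift this assay beyond the scatter. With no measured evidence pointing in either direction, the expectation is a step of a 1.6-fold higher number from compound 2 to compound 3 (0.19 log units; within the scatter), in effect close to no change beyond the scatter. Compound 3 is therefore expected to give about 2500 nM, within a range from 700 nM to 9000 nM.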

Compound 3, half-maximal inhibitory concentration: 20900 nM
Compound 3: middle estimate off by 8.4-fold (0.92 log units), on the low side; the whole stated range lies below it.
By their numbers in this assay, from the lowest: compound 2; then compounds 1 and 3 (each within the scatter of the next).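

Cyclopentyl in place of 3-chloro-4-fluorophenyl gives a 13-fold higher number from compound 2 to compound 3 (1.11 log units; beyond the scatter) in this assay and so shows that a swap from an aromatic ring to a five-membered non-aromatic ring at this nitrogen can move the number far beyond the scatter. Cyclopentyl in place of 2-chlorophenyl, however, gives a 1.8-fold higher number from compound 1 to compound 3 (0.27 log units; within the scatter) and so leaves those two groups within the scatter of each other: an aromatic ring on this nitrogen does not by itself go with the lower number, and among the three groups only 3-chloro-4-fluorophenyl stands apart. Nothing measured here explains this difference. The compounds shown leave open how 3-chlorophenyl or 4-fluorophenyl on this nitrogen would stand, and so which halogen goes with the lower number. They also leave open whether methyl or a piperidine ring would stand with cyclopentyl in this assay or apart from it.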